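This account rests on a few compounds, and the source may have more. Where it says the series, first, only, none or still open, it means among the compounds named here.

Compound 1 `CC(C)n1nccc1-c1ccccc1NCC1=NCCN1`: < 100000 nM
Compound 2 `CC(C)n1ncnc1-c1ccccc1NCC1=NCCN1`: < 100000 nM
Compound 3 `CCn1cccc1-c1ccccc1NCC1=NCCN1`: < 100000 nM

All three were tested in an in vitro functional assay on cells (Fibroblast) for agonist activity at Alpha-1B adrenergic receptor (Homo sapiens); a higher number here means that more compound is needed for the effect, a lower number that less compound is needed. The value recorded for compound 1 is a limit of the assay and not a number. The same holds for compound 2, whose entry is a limit as well. Compound 3, likewise, stands only at a limit, so where it sits among the three cannot be told from the numbers: as the limit of < 100000 nM in this assay, at which 3 of the 3 values shown sit, states, all three values rest at that same limit, and nothing separates them.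

The unmeasured compound 4 `Cn1cccc1-c1ccccc1NCC1=NCCN1` shares the core of compound 3 and differs from it by hydrogen in place of methyl on a saturated chain carbon bound to an aromatic nitrogen. Going by the values given here, no step between measured compounds has been recorded for this assay, so the size of this change cannot be read from any neighbouring pair. With every measured value at a limit, the step is expected to be none beyond the usual scatter, and compound 4 is expected to report a limit as well.

For compound 4 the estimated step from compound 3 is a step that the limit leaves unreadable from compound 3 to compound 4. Compound 4 is therefore expected to give 10000 nM in this assay, within a range from 500 nM to 100000 nM.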

Compound 4, half-maximal effective concentration: < 100000 nM
Compound 4: a limit, no number; the forecaster's own chance of this, stated with the estimate: 75%; the middle value does not contradict the limit.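

Compound 3 and compound 4 each stand only at a limit in this assay, so no step can be read for the change from ethyl to methyl. The compounds shown leave open how they rank against one another, because all rest at one limit: the limit of < 100000 nM in this assay, at which 4 of the 4 values shown sit.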